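Trimethoxyphenyl swap on a compound at the assay limit

This account rests on a few compounds, and the source may have more. Where it says the series, first, only, none or still open, it means among the compounds named here.

Compound 3 `CCN(CC)CCCn1c(=O)c(=Cc2ccc(F)cc2F)s/c1=C1\C(=O)Nc2ccc(Cl)cc21` stands only at a limit in a functional assay on HT-29 cells (Homo sapiens) for inhibition, read by MTT assay, with a stated time of 72 h (on this read-out lower numbers stand for stronger inhibition and higher numbers for weaker inhibition), reported as > 200000 nM, so no number of its own is known. Compound 1 `CCN(CC)CCCn1c(=O)c(=Cc2cc(OC)c(OC)c(OC)c2)s/c1=C1\C(=O)Nc2ccc(C)cc21` sits at a limit in this assay too, > 200000 nM. Compound 2 `CCN(CC)CCCn1c(=O)c(=Cc2ccc(F)c(F)c2)s/c1=C1\C(=O)Nc2cc(F)ccc21` gives 28 nM in this assay. Two of the three values are thus limits (the limit of > 200000 nM in this assay, at which 2 of the 3 values shown sit). Compound 4 `CCN(CC)CCCn1c(=O)c(=Cc2cc(OC)c(OC)c(OC)c2)s/c1=C1\C(=O)Nc2ccc(Cl)cc21` carries 3,4,5-trimethoxyphenyl in place of 2,4-difluorophenyl on a double-bonded chain carbon bound to an aromatic carbon. Within the data shown here, no single-change step between measured compounds covers this change. Compound 1, which also carries the trimethoxyphenyl group, stands at a limit of > 200000 nM. Compound 4 is therefore expected to give about 150000 nM in this assay, estimated between 10000 nM and 400000 nM. The estimated step of an at least 1.3-fold lower number from compound 3 to compound 4 (0.12 log units; that floor lies within the scatter) is expected to stay within the scatter, with a limit again likely.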

Compound 4, half-maximal inhibitory concentration: > 200000 nM
Compound 4 was reported as a limit; the forecaster's own chance of this, stated with the estimate: 60%; middle value at least 1.3-fold (0.12 log units) from the limit.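

In this assay, no step can be read from compound 3 to compound 4 or from compound 1 to compound 4, because all three compounds stand only at a limit: the limit of > 200000 nM in this assay, at which 3 of the 4 values shown sit.

From the compounds shown here alone, whether 3,4,5-trimethoxyphenyl in place of 2,4-difluorophenyl, or chloro in place of methyl, changes the read-out in this assay stays open.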